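The source may report more compounds than this note shows. Statements on the series, on what has been measured and on what is new or still open speak of the compounds shown alone.

Measured so far in a functional assay on A549 cells (Homo sapiens) for cytotoxicity, read by MTT assay, with a stated time of 48 h; a higher number here means a weaker inhibitor, a lower number a stronger inhibitor:
compound 1, `CC(C)n1c(/C=C2/C(=O)Nc3ccc(Br)cc32)nc2ccccc21`, gives 8630 nM;
compound 2, `CC(C)n1c(/C=C2/C(=O)Nc3ccc(F)cc32)nc2ccccc21`, gives 28500 nM;
compound 3, `Cn1c(/C=C2/C(=O)Nc3ccc(Br)cc32)nc2ccccc21`, gives 41200 nM.

Compound 4, `Cn1c(/C=C2/C(=O)Nc3ccc(F)cc32)nc2ccccc21`, has not yet been measured. It is made from compound 3 by one change, (fluoro in place of bromo on an aromatic carbon). The same change has already been made once, from compound 1 to compound 2, where it gave a 3.3-fold higher number from compound 1 to compound 2 (0.52 log units; beyond the scatter). The two cores on which the change is made are not identical: compound 3 differs from compound 1 by methyl in place of isopropyl on an aromatic nitrogen, a change that gave a 4.8-fold higher number from compound 1 to compound 3 (0.68 log units; beyond the scatter). The place of the change is described in exactly the same words for both pairs, so it is the same change, made on a second core. For compound 4 the expected step is a 2.7-fold higher number from compound 3 to compound 4 (0.43 log units; beyond the scatter), resting on the step from compound 1 to compound 2, a 3.3-fold higher number from compound 1 to compound 2 (0.52 log units; beyond the scatter), carried over to the core of compound 3. In this assay compound 4 is therefore estimated at 110000 nM, with a likely range from 45000 nM to 300000 nM.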

Compound 4, half-maximal inhibitory concentration: 34600 nM
Compound 4: the middle estimate sits 3.2-fold (0.50 log units) above what was measured, and the stated range ends above it.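

In this assay, fluoro in place of bromo did not behave on the second core as it did on the first: it gives a 1.2-fold lower number from compound 3 to compound 4 (0.08 log units; within the scatter), and the two steps do not agree: the same change on two cores in this assay, a 3.3-fold higher number (0.52 log units; beyond the scatter) from compound 1 to compound 2 and a 1.2-fold lower number (0.08 log units; within the scatter) from compound 3 to compound 4, 3.9-fold (0.59 log units) apart, beyond the scatter of two such steps

Seen from the other side of the same four compounds, methyl in place of isopropyl on the aromatic nitrogen gives a 1.2-fold higher number from compound 2 to compound 4 (0.08 log units; within the scatter), which also differs from its earlier step: the same change on two cores in this assay, a 4.8-fold higher number (0.68 log units; beyond the scatter) from compound 1 to compound 3 and a 1.2-fold higher number (0.08 log units; within the scatter) from compound 2 to compound 4, 3.9-fold (0.59 log units) apart, beyond the scatter of two such steps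

These two comparisons are one gap viewed in two ways, so they show that in this small set the effect of one change depends on the other group present, but they do not show why, nor how any further core would respond.

On these data alone, whether chloro or iodo in place of bromo would give a step like that on the core of compound 1 or like that on the core of compound 3 remains open. The same question stands for ethyl or a longer chain on the aromatic nitrogen.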